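Removing the Urea Substituent from the Aziridine Nitrile Core

The source may report more compounds than this note shows. Statements on the series, on what has been measured and on what is new or still open speak of the compounds shown alone.

Compound 1 `CCOC(=O)CNC(=O)N1CC1C#N`: 33000 nM
Compound 2 `CCCCNC(=O)N1CC1C#N`: 18000 nM
Compound 3 `CC(C)(C)NC(=O)N1CC1C#N`: > 300000 nM

In a functional assay on WiDr cells (Homo sapiens) for inhibition (on this read-out higher numbers stand for weaker inhibition and lower numbers for stronger inhibition), compound 1 gives 33000 nM and compound 2 gives 18000 nM, two numbers that sit close together. For compound 3 the read-out is only a limit, > 300000 nM, so compound 3 stands at the limit of > 300000 nM in this assay, at which 1 of the 3 values shown sits, and no exact number is known for it.

Compound 4 `N#CC1CN1C(N)=O` differs from compound 3 by hydrogen in place of tert-butyl on an amide-type nitrogen. Among the measured compounds shown here, the one measured step on that nitrogen is an at least 16-fold higher number from compound 2 to compound 3 (1.22 log units; beyond the scatter), a large worsening when the branched group replaced the straight chain. For the measured compounds named here, no measured pair shows the unsubstituted nitrogen itself. Compound 4 is therefore expected to fall back from the limit into the region of compounds 1 and 2, an estimated step of an at least 5.0-fold lower number from compound 3 to compound 4 (0.69 log units; beyond the scatter). Compound 4 is estimated at 60000 nM in this assay, with a range from 15000 nM to 300000 nM.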

Compound 4, half-maximal inhibitory concentration: > 280000 nM
Compound 4: no number, only a limit; the forecaster's own chance of this, stated with the estimate: 30%; middle value at least 4.6-fold (0.66 log units) away from the limit.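

Compound 4 gives no exact number, only a limit: the limit of > 280000 nM in this assay, at which 1 of the 4 values shown sits. Hydrogen on the amide-type nitrogen does not bring the read-out back to the level of compound 2, and the change from the butyl chain is large, with an at least 15-fold higher number from compound 2 to compound 4 (1.19 log units; beyond the scatter), so in this small set the straight chain is the better of the groups compared with both hydrogen and tert-butyl. Compound 3 and compound 4 both stand at limits, and the step between them cannot be read.

As far as these compounds go, whether a chain longer than butyl would give a lower number than compound 2 stays open. So does the effect of a carboxylic acid or an amine at the end of the butyl chain.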